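The source may hold more compounds than are shown below. What is called first, only, known or untested is meant among the compounds shown, and "the series" means these compounds.

Of the compounds shown here, three have so far been measured in an ADME assay for permeability, using PAMPA, with a stated time of 30 min, at pH 7.4; on this read-out lower numbers stand for lower permeability and higher numbers for higher permeability. Compound 3 `Clc1ccc(Oc2ccc3c(NCCCNCc4ccco4)ccnc3c2)cc1` gives 317 10^-6 cm/s, the highest of the three numbers. Compound 1 `COc1ccc(F)cc1CNCCCNc1ccnc2cc(Cc3ccc(F)cc3Cl)ccc12` gives 23 10^-6 cm/s, and compound 2 `CCC(CC)c1ccc2c(NCCCNCc3cc(F)ccc3OC)ccnc2c1` gives 23 10^-6 cm/s, each a long way beneath compound 3. Compound 4 `COc1ccc(F)cc1CNCCCNc1ccnc2cc(Oc3ccc(Cl)cc3)ccc12` has not been measured. It differs from compound 3 in one place: 5-fluoro-2-methoxyphenyl in place of furan-2-yl on a saturated chain carbon bound to an amine nitrogen. Compound 4 thus carries the same (5-fluoro-2-methoxybenzyl)amino group as compound 1 and compound 2, with everything else shared with compound 3. Among the measured compounds shown here, the one measured step, no change at the digits printed from compound 1 to compound 2 (within the scatter), concerns another position and does not bear on this change, and no measured pair shows the furan-2-yl to 5-fluoro-2-methoxyphenyl exchange. Because compound 1 gives 23 10^-6 cm/s and compound 2 gives 23 10^-6 cm/s while carrying this group, a lower number for compound 4 is expected, though of uncertain size. The step of a 5.3-fold lower number from compound 3 to compound 4 (0.72 log units; beyond the scatter) is therefore expected. Compound 4 is estimated at 60 10^-6 cm/s, within 20 10^-6 cm/s to 220 10^-6 cm/s.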

Compound 4, apparent permeability: 317 10^-6 cm/s
Compound 4: middle estimate off by 5.3-fold (0.72 log units), on the low side, and the stated range ends below it.
By their numbers in this assay, from the lowest: compounds 1 and 2 (each within the scatter of the next); then compounds 3 and 4 (each within the scatter of the next).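

In this assay, 5-fluoro-2-methoxyphenyl in place of furan-2-yl on a saturated chain carbon bound to an amine nitrogen gives no change at the digits printed from compound 3 to compound 4 (within the scatter), so this larger ring leaves the number unmoved here. With that group held fixed, 4-chlorophenoxy on an aromatic carbon gives a 14-fold higher number from compound 2 to compound 4 (1.14 log units; beyond the scatter) and a 14-fold higher number from compound 1 to compound 4 (1.14 log units; beyond the scatter), placing the gap with the aromatic-carbon group. Nothing available explains either result. As far as these compounds go, whether this exchange also stays flat with pentan-3-yl or 2-chloro-4-fluorobenzyl on the aromatic carbon remains open. So does the number for a pyridine ring in place of 5-fluoro-2-methoxyphenyl.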